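A Methyl Group and Cytotoxicity in Two Core Series

This account rests on a few compounds, and the source may have more. Where it says the series, first, only, none or still open, it means among the compounds named here.

compound 1, `CCOC(=O)c1cc2ccc(Oc3ccnc(C(=O)NC)c3)cc2s1`: > 100000 nM
compound 2, `CCOC(=O)c1sc2cc(Oc3ccnc(C(=O)NC)c3)ccc2c1C`: 50900 nM
compound 3, `CCOC(=O)c1cc2ccc(Oc3ccccc3)cc2s1`: > 100000 nM

In an ADME assay on H1-HeLa cells (Homo sapiens) for cytotoxicity, read by MTT assay, with a stated time of 3 days (on this read-out higher numbers stand for lower toxicity in this test and lower numbers for higher toxicity in this test), compound 1 reaches only a limit of the assay, > 100000 nM. Compound 2 gives a number, 50900 nM. The change between these two is methyl in place of hydrogen on an aromatic carbon, and the step it made is an at least 1.9-fold lower number from compound 1 to compound 2 (0.29 log units; that floor lies within the scatter). Compound 3 also sits at a limit in this assay, > 100000 nM. How the core of compound 3 differs from the core of compound 1 is not broken down here. Compound 4 `CCOC(=O)c1sc2cc(Oc3ccccc3)ccc2c1C` has not yet been measured in this assay; it differs from compound 3 by methyl in place of hydrogen on an aromatic carbon, the same change, at the same place, that separates compound 1 from compound 2. Of the three known values, two share one feature: the limit of > 100000 nM in this assay, at which 2 of the 3 values shown sit. For compound 4 a step of about an at least 1.6-fold lower number from compound 3 to compound 4 (0.22 log units; that floor lies within the scatter) is expected. That expectation rests on an at least 1.9-fold lower number from compound 1 to compound 2 (0.29 log units; that floor lies within the scatter). Compound 4 is therefore estimated at 60000 nM, with a real chance that this assay again returns only a limit rather than a number.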

Compound 4, half-maximal cytotoxic concentration: > 100000 nM
Compound 4: a limit, no number; the forecaster's own chance of this, stated with the estimate: 40%; at least 1.6-fold (0.22 log units) between middle value and limit.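

In this assay compound 4 returns only a limit, > 100000 nM. Compound 3 also stands at a limit, so no step can be read between compound 3 and compound 4. The compounds shown leave open what size, if any, the change of methyl in place of hydrogen on an aromatic carbon has on the core of compound 3, with most values resting at one limit: the limit of > 100000 nM in this assay, at which 3 of the 4 values shown sit.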